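The compounds below may be only part of what the source reports. "The series", "measured", "known", "first", "only" and "open" are said of these compounds alone.

Measured so far:
compound 1 `COc1cccc(N2CCNCC2)n1` — 30 mg/kg
compound 2 `CC(C)COc1cccc(N2CCNCC2)n1` — 10 mg/kg

For the measured compounds named here, in a functional assay on the whole organism with Mus musculus as the target, in the maximal electroshock model, with a stated time of 30 min (a higher number here means that more compound is needed for the effect, a lower number that less compound is needed), compound 2 gives the lowest of the two numbers; its only neighbour is compound 1, and the step of a 3.0-fold lower number from compound 1 to compound 2 (0.48 log units; beyond the scatter) is the sole measured step, arising from isopropyl in place of hydrogen on a saturated chain carbon bound to an oxygen on an aromatic ring. Compound 3 `CC(C)COc1cccc(N2CCN(C)CC2)n1` has not yet been measured. It differs from compound 2 by methyl in place of hydrogen on an amine nitrogen in a ring. Going by the values given here, no measured step touches the amine nitrogen in the ring; the one step, a 3.0-fold lower number from compound 1 to compound 2 (0.48 log units; beyond the scatter), concerns the chain on the oxygen and gives no guide to this change. The expectation for compound 3 in this assay is therefore anchored on compound 2 at 10 mg/kg, with a step no larger than the scatter and its direction left open. Compound 3 is estimated at 15 mg/kg, in the range 5 mg/kg to 45 mg/kg, which means an expected step of a 1.5-fold higher number from compound 2 to compound 3 (0.18 log units; within the scatter).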

Compound 3, minimum effective dose: 30 mg/kg
Compound 3: the middle estimate sits 2.0-fold (0.30 log units) below what was measured, within the range that was stated.
By their numbers in this assay, from the lowest: compound 2; then compounds 1 and 3 (each within the scatter of the next).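

In this assay, the amine nitrogen in the ring turns out not to be a silent position: methyl in place of hydrogen there gives a 3.0-fold higher number from compound 2 to compound 3 (0.48 log units; beyond the scatter) and so moves the number beyond the scatter, although only one heavy atom enters. The earlier step on the chain on the oxygen, a 3.0-fold lower number from compound 1 to compound 2 (0.48 log units; beyond the scatter) as printed, runs the other way, so the series now holds one change that lowers the number and one that raises it. Nothing available explains the effect of the methyl at this nitrogen.

As far as these compounds go, whether any group on this nitrogen raises the number, or only methyl does, stays open; an ethyl, a benzyl or a longer chain there would test this. Also open, from the compounds shown here alone, is whether the step carries over to other chains on the oxygen.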